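The source may report more compounds than this note shows. Statements on the series, on what has been measured and on what is new or still open speak of the compounds shown alone.

Measured so far in an in vivo ADME assay on the whole organism (strain CD1) for pharmacokinetics, with Mus musculus as the target, at a dose of 200 mg/kg by the oral route; on this read-out higher numbers stand for higher exposure at the dose given and lower numbers for lower exposure:
compound 1 `CCOC(=O)c1c(-c2cccc(Oc3ccccc3)c2)[nH]c2cc(OC)ccc2c1=O`: 400 nM
compound 2 `CCOC(=O)c1c(-c2cccc(Cl)c2)[nH]c2cc(OC)c(F)cc2c1=O`: 66000 nM
compound 3 `CCOC(=O)c1c(-c2cccc(Br)c2)[nH]c2cc(OC)c(F)cc2c1=O`: 39000 nM

Compound 3, at 39000 nM, cannot be told apart from compound 2 within the scatter, and it stands far above compound 1. The unmeasured compound 4 `CCOC(=O)c1c(-c2cc(F)cc(OC)c2)[nH]c2cc(OC)c(F)cc2c1=O` carries 3-fluoro-5-methoxyphenyl in place of 3-bromophenyl on an aromatic carbon.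

For the measured compounds named here, only one measured step bears directly on this change: a 1.7-fold lower number from compound 2 to compound 3 (0.23 log units; within the scatter). That swap of chloro for bromo stays within the scatter, but it exchanges one single atom for another, whereas compound 4 brings a different, two-group pattern on the ring. Compound 3 differs in more than one place from compound 1, so compound 1 at 400 nM serves only as a warning that much lower numbers occur among these compounds. A moderate fall in this assay is therefore expected, although no change beyond the scatter remains possible. The expected size is a 2.6-fold lower number from compound 3 to compound 4 (0.41 log units; beyond the scatter). Compound 4 is estimated at 15000 nM, within a range of 3000 nM to 50000 nM.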

Compound 4, maximal plasma concentration: 1600 nM
The estimate for compound 4 lay 9.4-fold (0.97 log units) above the measured number; measured number below the stated range.
By their numbers in this assay, from the lowest: compound 1; then compound 4; then compounds 3 and 2 (each within the scatter of the next).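

In this assay, putting 3-fluoro-5-methoxyphenyl in place of 3-bromophenyl gives a 24-fold lower number from compound 3 to compound 4 (1.39 log units; beyond the scatter) and putting it in place of 3-chlorophenyl gives a 41-fold lower number from compound 2 to compound 4 (1.62 log units; beyond the scatter) at the same position on the shared core. For the compounds shown here, the swap between the two halogens had stayed within the scatter, so only this new change shows that the group on this ring position can move exposure strongly. Nothing shown here gives a reason for the fall.

The compounds shown leave open whether the fluoro group, the methoxy group or the pair of them goes with the lower exposure, and a phenyl ring carrying methoxy alone or fluoro alone would separate these cases. From the compounds shown here alone, how an amine or a carboxylic acid on this phenyl ring would behave also remains open.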